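A few compounds are considered here, and "the series" means these few. Any claim that something is new, unique, unknown or untested is made for them only; others in the source may bear on it.

Of the compounds shown here, three sharing one core have been measured in a functional assay on PBMC cells (Homo sapiens) for inhibition, read by ELISA, BrdU incorporation and thymidine incorporation, with a stated time of 72 h; on this read-out lower numbers stand for stronger inhibition and higher numbers for weaker inhibition: compound 1 (`CC/C(O)=C(\C#N)C(=O)Nc1ccc(-c2ccc(F)cc2)c(C(=O)OC)c1`) gives 2000 nM, compound 2 (`CC/C(O)=C(\C#N)C(=O)Nc1ccc(-c2cccc(Cl)c2)c(C(=O)OC)c1`) gives 34000 nM, and compound 3 (`CC/C(O)=C(\C#N)C(=O)Nc1ccc(-c2ccc(Cl)cc2)c(C(=O)OC)c1`) gives 13000 nM. Compound 3 therefore has the second highest of the three numbers. The next compound, compound 4 (`CC/C(O)=C(\C#N)C(=O)Nc1ccc(-c2ccc(F)cc2F)c(C(=O)OC)c1`), carries a 2,4-difluorophenyl in place of the 4-chlorophenyl of compound 3, on an aromatic carbon ortho to a methoxycarbonyl group: 2,4-difluorophenyl in place of 4-chlorophenyl on an aromatic carbon. The closest guide is a 6.5-fold higher number from compound 1 to compound 3 (0.81 log units; beyond the scatter), where chloro takes the place of fluoro. Compound 4 returns to fluoro, so much of that step may be reversed. The other two measured steps, a 17-fold higher number from compound 1 to compound 2 (1.23 log units; beyond the scatter) and a 2.6-fold lower number from compound 2 to compound 3 (0.42 log units; beyond the scatter), show that changes on this same group can move the number beyond the scatter. For the measured compounds named here, no measured compound has a 2,4-difluorophenyl, so the effect of the added fluoro group is unknown and the range has to stay wide. In this assay, the expected change is a 3.3-fold lower number from compound 3 to compound 4 (0.51 log units; beyond the scatter), a move to a lower number. For compound 4, the estimated value is 4000 nM, with an expected range from 1200 nM to 13000 nM.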

Compound 4, half-maximal inhibitory concentration: 6000 nM
Compound 4: the middle estimate sits 1.5-fold (0.18 log units) below what was measured; low and high end bracket the measured number.
By their numbers in this assay, from the lowest: compound 1; then compound 4; then compound 3; then compound 2.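

In this assay, for the compounds shown here, the step to compound 4 gives the first reading of a second fluoro on this phenyl ring, and it does not help: there is a 3.0-fold higher number from compound 1 to compound 4 (0.48 log units; beyond the scatter), beyond the scatter. The fluoro-bearing rings still keep their lead over the chloro-bearing ones, with a 2.2-fold lower number from compound 3 to compound 4 (0.34 log units; beyond the scatter) and a 5.7-fold lower number from compound 2 to compound 4 (0.75 log units; beyond the scatter), so all four compounds now fall into two groups: compound 1 and compound 4 with fluoro have lower numbers, and compound 2 and compound 3 with chloro have higher ones, with no exception among these four. Nothing beyond these inhibition numbers is available to explain the size or direction of these steps.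

As far as these compounds go, it remains open whether the higher number of compound 4 belongs to the added fluoro wherever it sits on the ring, or only to the arrangement found in the 2,4-difluorophenyl group. From the compounds shown here alone, it is also open how a plain phenyl ring, or a phenyl ring carrying a methoxy group or an amine, would compare, and whether a carboxylic acid in place of the methyl ester of the methoxycarbonyl group would preserve the same order.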